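A Hydroxypiperidine Amide in Place of an Ethylpiperidine

The compounds below may be only part of what the source reports. "The series", "measured", "known", "first", "only" and "open" are said of these compounds alone.

Of the compounds shown here, three sharing one core have been measured in an assay on HEK293 cells for displacement of a labelled ligand from NPC1-like intracellular cholesterol transporter 1 (Homo sapiens); on this read-out lower numbers stand for stronger inhibition and higher numbers for weaker inhibition. Compound 1 `CC(C)(C)c1ccc(C(=O)N2CCC3(CC2)C(=O)N(CC(=O)NCCO)CN3c2ccccc2)cc1` gives 1000 nM, compound 2 `CC(C)(C)c1ccc(C(=O)N2CCC3(CC2)C(=O)N(CC(=O)NCCN)CN3c2ccccc2)cc1` gives 7000 nM, and compound 3 `CCC1CCCN(C(=O)CN2CN(c3ccccc3)C3(CCN(C(=O)c4ccc(C(C)(C)C)cc4)CC3)C2=O)C1` gives 3900 nM. Compound 3 stands second highest of the three numbers: the step of a 1.8-fold lower number from compound 2 to compound 3 (0.25 log units; within the scatter) is within the scatter, whereas the step of a 3.9-fold higher number from compound 1 to compound 3 (0.59 log units; beyond the scatter) lies beyond it. Compound 4 `CC(C)(C)c1ccc(C(=O)N2CCC3(CC2)C(=O)N(CC(=O)N2CCC(O)CC2)CN3c2ccccc2)cc1` has not been measured; it differs from compound 3 in one place, (4-hydroxypiperidin-1-yl in place of 3-ethylpiperidin-1-yl on a carbonyl carbon). Within the data shown here, two measured steps bear on this change. The step of a 3.9-fold higher number from compound 1 to compound 3 (0.59 log units; beyond the scatter) shows that the amide bearing (2-hydroxyethyl)amino gave a lower number than the 3-ethylpiperidin-1-yl amide, while the step of a 1.8-fold lower number from compound 2 to compound 3 (0.25 log units; within the scatter) shows no difference beyond the scatter for the (2-aminoethyl)amino amide. Because the step of a 3.9-fold higher number from compound 1 to compound 3 (0.59 log units; beyond the scatter) lies beyond the scatter and compound 4 brings a hydroxy group back through 4-hydroxypiperidin-1-yl, a modest downward step, a 2.0-fold lower number from compound 3 to compound 4 (0.29 log units; within the scatter), is expected for compound 4 in this assay. Compound 4 is estimated at 2000 nM, with a range from 800 nM to 6000 nM.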

Compound 4, half-maximal inhibitory concentration: 4700 nM
Compound 4: middle estimate off by 2.4-fold (0.37 log units), on the low side; low and high end bracket the measured number.
By their numbers in this assay, from the lowest: compound 1; then compounds 3, 4 and 2 (each within the scatter of the next).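

In this assay, placing 4-hydroxypiperidin-1-yl instead of 3-ethylpiperidin-1-yl on this carbonyl carbon gives a 1.2-fold higher number from compound 3 to compound 4 (0.08 log units; within the scatter), so the entering group's hydrogen-bond donor and acceptor do not separate the two ring amides in this read-out. The step of a 1.5-fold lower number from compound 2 to compound 4 (0.17 log units; within the scatter) shows no separation from the (2-aminoethyl)amino amide either, whereas a 4.7-fold higher number from compound 1 to compound 4 (0.67 log units; beyond the scatter) leaves the (2-hydroxyethyl)amino amide of compound 1 with the lowest number, showing that a hydroxy group in this amide does not by itself go with that number. Nothing measured here accounts for these steps.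

Still open, as far as these compounds go, is how an unsubstituted piperidin-1-yl amide, a morpholin-4-yl amide or a longer chain such as (3-hydroxypropyl)amino would read on this carbonyl carbon. Also open, from the compounds shown here alone, is whether the amide hydrogen, present in compound 1 and compound 2 but absent from compound 3 and compound 4, has any bearing on the number.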